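A few compounds are considered here, and "the series" means these few. Any claim that something is new, unique, unknown or untested is made for them only; others in the source may bear on it.

Compound 1 `COc1cccc(-c2c(S(=O)(=O)c3ccc(C)c(F)c3)cnc3c(F)cccc23)c1` and compound 2 `Cc1ccc(S(=O)(=O)c2cnc3c(F)cccc3c2-c2ccc(F)cc2)cc1F` differ in one place. In an ADME assay on microsomes from liver (Homo sapiens) for metabolic stability, tested at 2.5 uM (a lower number here means slower removal, a higher number faster removal of the compound), compound 1 gives 4.02 mL/min and compound 2 gives 2.75 mL/min, the step of a 1.5-fold lower number from compound 1 to compound 2 (0.16 log units; within the scatter) leaving the two within the scatter of each other, so compound 2 stands within the scatter of compound 1 on these two numbers. Compound 3 `O=S(=O)(c1cccc(F)c1)c1cnc2c(F)cccc2c1-c1ccc(F)cc1` differs from compound 2 by hydrogen in place of methyl on an aromatic carbon. For the measured compounds named here, no measured step touches this position, since the one step known alters another group. A step no larger than the scatter is therefore expected, a 1.1-fold lower number from compound 2 to compound 3 (0.04 log units; within the scatter). For compound 3 the estimate in this assay is 2.5 mL/min, expected to fall between 1.3 mL/min and 5 mL/min.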

Compound 3, intrinsic clearance in a liver preparation (reported as CLH), per the amount of preparation that the assay uses: 0.19 mL/min
The estimate for compound 3 lay 13-fold (1.12 log units) above the measured number; measured number outside the range, below it.
By their numbers in this assay, from the lowest: compound 3; then compounds 2 and 1 (each within the scatter of the next).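

In this assay, going from 3-fluoro-4-methylphenyl to 3-fluorophenyl gives a 14-fold lower number from compound 2 to compound 3 (1.16 log units; beyond the scatter), so the methyl position, ortho to a fluoro group and para to a large group, is a sensitive point in this series. For the compounds shown here, the only earlier step, a 1.5-fold lower number from compound 1 to compound 2 (0.16 log units; within the scatter), changed another group and stayed within the scatter, giving no sign of this sensitivity. Nothing available accounts for the size of the new step.

Open, from the compounds shown here alone, is how a chloro group or an amine at this carbon would read in this assay. Also open, going by these compounds, is whether the same exchange of methyl for hydrogen carries over when 3-methoxyphenyl replaces 4-fluorophenyl.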